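Ester variations on a shared bicyclic core against kallikrein-7

A few compounds are considered here, and "the series" means these few. Any claim that something is new, unique, unknown or untested is made for them only; others in the source may bear on it.

Measured compounds:
- Compound 1, `CC(C)(C)OC(=O)N1CCC[C@H]1C(=O)O[C@@H]1CO[C@H]2[C@@H]1OC[C@H]2OCc1ccccc1`: 15600 nM
- Compound 2, `CC(C)[C@@H](NC(=O)OC(C)(C)C)C(=O)O[C@@H]1CO[C@H]2[C@@H]1OC[C@H]2OCc1ccccc1`: "not determined" (no result reported)

Compound 1 carries a cyclic amino acid ester on the shared core and, in an assay for inhibition of kallikrein-7 (Homo sapiens), using Lineweaver-Burk analysis, with a stated time of 5 min (on this read-out higher numbers stand for weaker inhibition and lower numbers for stronger inhibition), compound 1 gives 15600 nM, a weak result on this scale. Compound 2 replaces that cyclic amino acid with an open-chain one bearing an isopropyl group; in this assay compound 2 gives "not determined" (no result reported), so nothing can be said about where it stands, and no comparison between compound 1 and compound 2 is possible from the values alone.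

Compound 3, `CC(C)(C)OC(=O)N[C@H](COCc1ccccc1)C(=O)O[C@@H]1CO[C@H]2[C@@H]1OC[C@H]2OCc1ccccc1`, has not yet been measured. It differs from compound 2 in one place: (benzyloxy)methyl in place of isopropyl on a saturated chain carbon bound to an amide-type nitrogen and a carbonyl carbon. Since compound 2 has no value, there is no measured starting point for this step, and the only anchor for the whole series is the weak result of compound 1. The step is expected to be modest and its direction uncertain, most likely not clearly beyond the scatter in this assay.

On that basis compound 3 is estimated to give 12000 nM in this assay, with a plausible range from 3000 nM to 50000 nM.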

Compound 3, inhibition constant: 2300 nM
Compound 3: the middle estimate sits 5.2-fold (0.72 log units) above what was measured; measured number below the stated range.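

No step can be read from the result for compound 3: compound 2, which differs from it in one place, has no reported value, and compound 1 differs from it in more than one place. The compounds shown leave open how (benzyloxy)methyl in place of isopropyl changes inhibition. No measured evidence bears on this result.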